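Replacing the 3,4-dihydroxyphenyl group of compound 3

A few compounds are considered here, and "the series" means these few. Any claim that something is new, unique, unknown or untested is made for them only; others in the source may bear on it.

Values measured so far in a functional assay on DU-145 cells (Homo sapiens) for cytotoxicity (a lower number here means a stronger inhibitor of growth, a higher number a weaker inhibitor of growth), are as follows:
- compound 1 `COc1ccc(C2=C(c3cc(OC)c(OC)c(OC)c3)CC3CCCN3C2=O)cc1O` gives > 100000 nM as a limit of the assay and not a number
- compound 2 `COc1ccc(C2=C(c3ccc(SC)cc3)CC3CCCN3C2=O)cc1OC` gives 1500 nM as a measured number
- compound 3 `CSc1ccc(C2=C(c3ccc(O)c(O)c3)C(=O)N3CCCC3C2)cc1` gives 60000 nM as a measured number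

Of the two true numbers, compound 3 holds the higher, and its gap to compound 2 lies beyond the scatter. Compound 4 `CSc1ccc(C2=C(c3ccc(C)cc3)C(=O)N3CCCC3C2)cc1` is not yet measured. The change is 4-methylphenyl in place of 3,4-dihydroxyphenyl on a double-bonded ring carbon in the words of 4-methylphenyl in place of 3,4-dihydroxyphenyl on a double-bonded ring carbon.

Among the compounds with values here, no measured step isolates this change. Compound 2 also lacks the 3,4-dihydroxyphenyl group and gives 1500 nM in this assay so a lower number is expected here. Compound 1 lacks that group too, yet it stands at a limit of the assay, so the range stays wide. The expected move is a 10-fold lower number from compound 3 to compound 4 (1.00 log units; beyond the scatter) toward a lower number and beyond the scatter. In this assay compound 4 is estimated at 6000 nM with an expected range from 1000 nM to 40000 nM for a measurement.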

Compound 4, concentration for 50% growth inhibition: 600 nM
Compound 4: the middle estimate sits 10-fold (1.00 log units) above what was measured, outside the stated range (below it).
By their numbers in this assay, from the lowest: compound 4; then compound 2; then compound 3. At a limit, above all of these: compound 1.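

Within the data shown here, compound 3 and compound 4 give the first measured step that isolates this position, the double-bonded ring carbon two ring bonds from the ring nitrogen. In this assay, 4-methylphenyl in place of 3,4-dihydroxyphenyl gives a 100-fold lower number from compound 3 to compound 4 (2.00 log units; beyond the scatter). The position is therefore sensitive to this substituent on the shared core, and the change removes 2 hydrogen-bond donors and 2 hydrogen-bond acceptors while the aromatic ring stays in place.

A plain phenyl, a 4-hydroxyphenyl or a 4-aminophenyl at this carbon would separate the loss of the hydroxyl groups from the gain of the methyl, which this single step cannot do. Compound 1 remains a limit and not a number, and it gives no measured step at this position: the limit of > 100000 nM in this assay, at which 1 of the 4 values shown sits.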